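The compounds below may be only part of what the source reports. "The series", "measured", "known", "first", "only" and "open" are said of these compounds alone.

Measured so far in a functional assay on HeLa cells (Homo sapiens) for antiproliferative activity, with a stated time of 24 h; on this read-out lower numbers stand for stronger inhibition and higher numbers for weaker inhibition: compound 1 `NC(=O)c1c(NC(=O)c2ccccc2F)sc2c1CCN(C(=S)Nc1ccccc1Cl)C2` gives 19400 nM; compound 3 `NC(=O)c1c(NC(=O)c2cccc([N+](=O)[O-])c2)sc2c1CCN(C(=S)Nc1ccccc1Cl)C2` gives 40300 nM. Compound 2 `NC(=O)c1c(NC(=O)c2ccccc2F)sc2c1CCN(C(=O)Nc1ccccc1Cl)C2` reaches only a limit of the assay, > 50000 nM.

One structural change, (a group of 10 heavy atoms (7 carbon, 1 nitrogen, 1 oxygen, 1 chlorine; one six-membered aromatic ring of carbon only) in place of a group of 10 heavy atoms (7 carbon, 1 nitrogen, 1 sulfur, 1 chlorine; one six-membered aromatic ring of carbon only), on an amine nitrogen in a ring), turns compound 1 into compound 2, and the same change, (a group of 10 heavy atoms (7 carbon, 1 nitrogen, 1 oxygen, 1 chlorine; one six-membered aromatic ring of carbon only) in place of a group of 10 heavy atoms (7 carbon, 1 nitrogen, 1 sulfur, 1 chlorine; one six-membered aromatic ring of carbon only), on an amine nitrogen in a ring), turns compound 3 into compound 4 `NC(=O)c1c(NC(=O)c2cccc([N+](=O)[O-])c2)sc2c1CCN(C(=O)Nc1ccccc1Cl)C2`, which is not yet measured. In the measured pair it gave an at least 2.5-fold higher number from compound 1 to compound 2 (0.41 log units; beyond the scatter). The two starting cores differ by 3-nitrophenyl in place of 2-fluorophenyl on a carbonyl carbon, a change that gave a 2.1-fold higher number from compound 1 to compound 3 (0.32 log units; beyond the scatter). The place of the change is the same in both pairs, so it is the same change on a core that already tests weaker.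

For compound 4 a step of about a 2.7-fold higher number from compound 3 to compound 4 (0.44 log units; beyond the scatter) is expected, resting on the step seen for compound 1 to compound 2 an at least 2.5-fold higher number from compound 1 to compound 2 (0.41 log units; beyond the scatter) and on compound 3 starting from 40300 nM. That starting number lies not far from the limit of > 50000 nM in this assay, at which 1 of the 3 values shown sits, so the assay may again report only a limit for compound 4. Compound 4 is therefore estimated at 110000 nM, within 45000 nM to 300000 nM.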

Compound 4, half-maximal inhibitory concentration: > 50000 nM
Compound 4: only a limit was reported; the forecaster's own chance of this, stated with the estimate: 80%; the middle value is on the limit's open side.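

In this assay compound 4 reaches only a limit of the assay, > 50000 nM, not a true number. Replacing the sulfur-containing group with (2-chlorophenyl)carbamoyl therefore again leaves a weak result, with an at least 1.2-fold higher number from compound 3 to compound 4 (0.09 log units; that floor lies within the scatter), while the step between the limits of compound 2 and compound 4 cannot be read. This fits the change carrying over to the second core, but does not show that its size is the same: the same change on two cores in this assay, an at least 2.5-fold higher number (0.41 log units; beyond the scatter) from compound 1 to compound 2 and an at least 1.2-fold higher number (0.09 log units; that floor lies within the scatter) from compound 3 to compound 4; the limit leaves it open whether they differ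

On these data alone, how much weaker the two oxygen-containing compounds really are stays open: the limit of > 50000 nM in this assay, at which 2 of the 4 values shown sit. Also open is how the change would behave with an amine or a carboxylic acid in place of 3-nitrophenyl on the carbonyl carbon.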